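Fluoro for Methyl on the Aryl Group of Compound 1

The compounds below may be only part of what the source reports. "The series", "measured", "known", "first", "only" and "open" are said of these compounds alone.

Compound 1 `C#CCO/N=C/c1c(-c2ccc(C)cc2)nc2c(C)cccn12` was tested in a functional assay on the whole organism (strain NMRI) with Mus musculus as the target, with a stated time of 4 h (a higher number here means that more compound is needed for the effect, a lower number that less compound is needed), and gives 20 mg/kg. Compound 2 `COc1ccc(Cn2cc(CO/N=C/c3c(-c4ccccc4)nc4c(C)cccn34)nn2)cc1` gives 100 mg/kg in this assay; compound 1 thus stands at the lower of the two numbers, and its gap to compound 2 lies beyond the scatter. Compound 3 `C#CCO/N=C/c1c(-c2ccc(F)cc2)nc2c(C)cccn12` differs from compound 1 in one place: fluoro in place of methyl on an aromatic carbon. Among the measured compounds shown here, no step between measured compounds mirrors this change, so the step of no change at the digits printed from compound 1 to compound 3 (within the scatter) is expected to be none beyond the scatter. Compound 3 is therefore estimated at 20 mg/kg, within 10 mg/kg to 50 mg/kg.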

Compound 3, minimum effective dose: 100 mg/kg
Compound 3: middle estimate off by 5.0-fold (0.70 log units), on the low side; the whole stated range lies below it.
By their numbers in this assay, from the lowest: compound 1; then compounds 2 and 3 (each within the scatter of the next).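

Exchanging 4-methylphenyl for 4-fluorophenyl gives a 5.0-fold higher number from compound 1 to compound 3 (0.70 log units; beyond the scatter) in this assay, so this position, para to a large group, responds to the change of a single heavy atom. The earlier compounds shown here formed no pair differing in one place and could not show this. Nothing at hand explains the step. On these data alone, how a chloro, an ethyl or an amine at this position would compare with methyl and fluoro stays open, as does whether the step would hold with another group on the oxime oxygen.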